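Lengthening the chain on an oxygen next to a carbonyl

A few compounds are considered here, and "the series" means these few. Any claim that something is new, unique, unknown or untested is made for them only; others in the source may bear on it.

Measured so far in an assay on isolated protein for inhibition of patatin-like phospholipase domain-containing protein 2 (Mus musculus), tested at 200 uM; on this read-out lower numbers stand for less inhibition and higher numbers for more inhibition at the one concentration tested (going by the name of the read-out):
compound 1, `CCOC(=O)c1nn(-c2ccc(OCC)cc2)cc1O`: 67%
compound 2, `CCOc1ccc(-n2cc(O)c(C(=O)O)n2)cc1`: 15%
compound 3, `CCOc1ccc(-n2cc(O)c(C(=O)OC)n2)cc1`: 64%

Compound 3 stands second highest of the three numbers. Its nearest neighbour is compound 1, and the step of a number 3 percentage points lower from compound 1 to compound 3 (within the scatter) lies within the scatter, so the two cannot be ranked against each other. Its furthest neighbour is compound 2, and the step of a number 49 percentage points higher from compound 2 to compound 3 (beyond the scatter) is large and well beyond the scatter; in the same way, a number 52 percentage points lower from compound 1 to compound 2 (beyond the scatter) is large. Both large steps involve a hydrogen in place of an alkyl group on the oxygen next to the carbonyl group, not a change in the length of the chain.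

Compound 4, `CCCCOC(=O)c1nn(-c2ccc(OCC)cc2)cc1O`, has not yet been measured in this assay. It differs from compound 3 as follows: propyl in place of hydrogen on a saturated chain carbon bound to an oxygen next to a carbonyl group.

For the measured compounds named here, the only measured step that changes the length of that chain is a number 3 percentage points lower from compound 1 to compound 3 (within the scatter), and it stays within the scatter. Going by the values given here, no measured step speaks to a chain as long as butyl, so the expectation rests on that one step. Compound 4 is therefore expected to show a number 1 percentage points lower from compound 3 to compound 4 (within the scatter), no step beyond the scatter. Compound 4 is estimated at 63%, with a range from 45% to 80%.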

Compound 4, a percentage reported as inhibition, at one concentration (the size of the read-out at that concentration, not a potency): 74%
Beside the measured number, compound 4's estimate is 11 percentage points below it; low and high end bracket the measured number.
By their numbers in this assay, from the lowest: compound 2; then compounds 3, 1 and 4 (each within the scatter of the next).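

In this assay, the chain on the oxygen next to a carbonyl group now reaches butyl, and the methoxycarbonyl to butoxycarbonyl change gives a number 10 percentage points higher from compound 3 to compound 4 (within the scatter). Measured against the ethyl chain of compound 1, the result is a number 7 percentage points higher from compound 1 to compound 4 (within the scatter), so methyl, ethyl and butyl at this position cannot be ranked against one another in this assay. The large gap already seen for the two shorter chains against hydrogen on that oxygen also holds for the longest chain shown, with a number 59 percentage points higher from compound 2 to compound 4 (beyond the scatter), and none of the compounds shown goes against this split between hydrogen and an alkyl chain.

No evidence is at hand on why hydrogen on that oxygen stands apart from the three alkyl chains. Still open, going by these compounds, is whether a chain longer than butyl, a branched chain such as isopropyl, or an amide in place of the oxygen and its chain would stay level with these three, and all of these numbers describe a single tested concentration, so they give no potency.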